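A 5-methoxypyridin-3-yl group on the shared core

A few compounds are considered here, and "the series" means these few. Any claim that something is new, unique, unknown or untested is made for them only; others in the source may bear on it.

In an ADME assay (liver) for metabolic stability, with Liver microsome (Homo sapiens) as the target, using microsomes and NADPH, with a stated time of 30 min, tested at 1 uM (on this read-out higher numbers stand for fast clearance and lower numbers for slow clearance), compound 1 (`CS(=O)(=O)c1ccc(-c2cc(C(O)(C(F)(F)F)C(F)(F)F)cnc2N2CCN(S(=O)(=O)c3ccc(N)nc3)CC2)cc1`) gives 32 mL.min-1.g-1 and compound 2 (`Nc1ccc(S(=O)(=O)N2CCN(c3ncc(C(O)(C(F)(F)F)C(F)(F)F)cc3-c3ccncc3)CC2)cn1`) gives 15 mL.min-1.g-1 as the lower of the two numbers. Compound 3 (`COc1cncc(-c2cc(C(O)(C(F)(F)F)C(F)(F)F)cnc2N2CCN(S(=O)(=O)c3ccc(N)nc3)CC2)c1`) keeps the core of compound 2 and differs from it in one place (5-methoxypyridin-3-yl in place of pyridin-4-yl on an aromatic carbon), with 5-methoxypyridin-3-yl in place of pyridin-4-yl on an aromatic carbon. Going by the values given here, only one measured step bears on this change. It concerns the same aromatic carbon, with pyridin-4-yl in place of 4-(methylsulfonyl)phenyl, and it amounts to a 2.1-fold lower number from compound 1 to compound 2 (0.33 log units; beyond the scatter) in this assay as a modest change. Among the compounds with values here, no measured compound carries a 5-methoxypyridin-3-yl group, so that single step gives only a rough scale. A step no larger than that one is expected here, and upward if it can be seen at all. The estimated step is a 1.5-fold higher number from compound 2 to compound 3 (0.17 log units; within the scatter) in this assay on this reasoning. In this assay compound 3 is expected at 22 mL.min-1.g-1 with a range from 11 mL.min-1.g-1 to 42 mL.min-1.g-1 as estimated here.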

Compound 3, intrinsic clearance in microsomes: 44 mL.min-1.g-1
Compound 3: the middle estimate sits 2.0-fold (0.30 log units) below what was measured; measured number above the stated range.
By their numbers in this assay, from the lowest: compound 2; then compounds 1 and 3 (each within the scatter of the next).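

In this assay, going by these compounds alone, the aromatic carbon ortho to a large group proves more sensitive to the choice of ring than the single earlier step could show, with a 2.9-fold higher number from compound 2 to compound 3 (0.47 log units; beyond the scatter), so the lower number of compound 2 does not carry over to the 5-methoxypyridin-3-yl group. Set against the 4-(methylsulfonyl)phenyl group, the same group gives a 1.4-fold higher number from compound 1 to compound 3 (0.14 log units; within the scatter), which leaves compound 1 and compound 3 indistinguishable here and makes pyridin-4-yl the only one of the three groups that stands apart, so a ring nitrogen in the entering group does not by itself hold the number at the level of compound 2. Nothing among the data given accounts for this difference between the two pyridine groups.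

The change from compound 2 to compound 3 moves the point of attachment and adds a methoxy group in a single step, and the compounds shown cannot divide the effect between the two; the plain pyridin-3-yl group would separate them. From the compounds shown here alone, it also remains open whether a different substituent at that ring position, such as a dimethylamino group or a fluorine atom, would behave like the methoxy group.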